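A few compounds are considered here, and "the series" means these few. Any claim that something is new, unique, unknown or untested is made for them only; others in the source may bear on it.

The shared core of this series appears in compound 1 `CC1CCC(=NNc2ccccc2)c2ncc(C(=O)NO)c(=O)n21`. In a functional assay on the whole organism with Rattus norvegicus as the target (on this read-out lower numbers stand for an effect already at smaller amounts and higher numbers for an effect only at larger amounts of compound), compound 1 gives only a limit, > 100 umol/kg, and not a number. Compound 2 `Cc1cccc(NN=C2CCC(C)n3c2ncc(C(=O)O)c3=O)c1C` carries a 2,3-dimethylphenyl on the amine nitrogen. In this assay compound 2 likewise gives only a limit, > 100 umol/kg. Compound 3 `Cc1cccc(Cl)c1NN=C1CCC(C)n2c1ncc(C(=O)O)c2=O`, with 2-chloro-6-methylphenyl in place of 2,3-dimethylphenyl on that nitrogen, gives in this assay also a limit, > 100 umol/kg. The step that the two limits leave unreadable from compound 2 to compound 3 therefore cannot be sized; all three measured compounds share (the limit of > 100 umol/kg in this assay, at which 3 of the 3 values shown sit), so compound 2 stands with the others and no order among them can be read.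

Compound 4 `CC1CCC(=NNc2ccccn2)c2ncc(C(=O)O)c(=O)n21` differs from compound 2 as follows: pyridin-2-yl in place of 2,3-dimethylphenyl on an amine nitrogen. For the measured compounds named here, no measured step reports a change of this kind, and the only step in the set, from compound 2 to compound 3, is unreadable. With every compound sitting at the same limit, the expectation for compound 4 in this assay is a value at or around that limit, an estimated step that the limit leaves unreadable from compound 2 to compound 4 of no size beyond the scatter. Compound 4 is thus expected to give about 150 umol/kg, within 40 umol/kg to 600 umol/kg, most probably again as a limit.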

Compound 4, dose for 50% inhibition: > 100 umol/kg
Compound 4 ended at the assay's limit (the forecaster's own chance of this, stated with the estimate: 80%); the middle value lies beyond the limit too.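

In this assay compound 4 gives > 100 umol/kg, a limit and not a number. The steps to compound 4 from compound 2 and from compound 3 therefore cannot be read. The compounds shown leave open how any of these groups on the amine nitrogen compares with the others: the limit of > 100 umol/kg in this assay, at which 4 of the 4 values shown sit.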